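Dimethylamino variant of compound 2: cytotoxicity outlook

This account rests on a few compounds, and the source may have more. Where it says the series, first, only, none or still open, it means among the compounds named here.

Compound 2 `C#CCNc1nc(N)nc2c1ncn2[C@H]1C[C@H](N=[N+]=[N-])[C@@H](CO)O1` reaches no number in an ADME assay on PBMC cells (Homo sapiens) for cytotoxicity, with a stated time of 5 days; on this read-out higher numbers stand for weaker inhibition and lower numbers for stronger inhibition: its value > 100000 nM is a limit of the assay. (the limit of > 100000 nM in this assay, at which 1 of the 3 values shown sits). For the measured compounds named here, compound 1 `[N-]=[N+]=N[C@H]1C[C@H](n2cnc3c(N)nc(F)nc32)O[C@@H]1CO` gives 30100 nM and compound 3 `COc1nc(F)nc2c1ncn2[C@H]1C[C@H](N=[N+]=[N-])[C@@H](CO)O1` gives 9400 nM in this assay; the one measured single-point step, a 3.2-fold lower number from compound 1 to compound 3 (0.51 log units; beyond the scatter), concerns a different pair of groups at an aromatic carbon and bears on the present change only loosely. Compound 4 `CN(C)c1nc(N)nc2c1ncn2[C@H]1C[C@H](N=[N+]=[N-])[C@@H](CO)O1` differs from compound 2 as follows: dimethylamino in place of propargylamino on an aromatic carbon. Going by the values given here, no measured step covers dimethylamino in place of propargylamino, so no step beyond the scatter is anticipated, and a limit again seems likely. Compound 4 is expected near 100000 nM (range 40000 nM to 250000 nM), a step of a number no higher from compound 2 to compound 4 (the limit leaves the size open).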

Compound 4, half-maximal inhibitory concentration: > 100000 nM
Compound 4 ended at the assay's limit; the forecaster's own chance of this, stated with the estimate: 60%; the middle value lies on the limit itself.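

For the compounds shown here, no step from compound 2 to compound 4 can be read, because both stand at a limit rather than a number: the limit of > 100000 nM in this assay, at which 2 of the 4 values shown sit. In this assay the compounds shown leave open how dimethylamino and propargylamino compare on this core.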